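Replacing the aromatic substituent on the thiosemicarbazone arm

A few compounds are considered here, and "the series" means these few. Any claim that something is new, unique, unknown or untested is made for them only; others in the source may bear on it.

Measured so far:
compound 1, `CC1=CC[C@@H]([C@@](C)(O)CCCC(C)(C)NC(=S)N/N=C\c2ccccc2)CC1`: 23800 nM
compound 2, `CC1=CC[C@@H]([C@@](C)(O)CCCC(C)(C)NC(=S)N/N=C\c2ccc(N(C)C)cc2)CC1`: > 100000 nM

Compound 1 and compound 2 share one core and differ only in the group on the aromatic ring. In a functional assay on NCI/ADR cells (Homo sapiens) for cytotoxicity, read by sulforhodamine B assay (on this read-out lower numbers stand for stronger inhibition of growth and higher numbers for weaker inhibition of growth), compound 1 gives 23800 nM. For compound 2 this assay reports only a limit, > 100000 nM, not a number, so compound 2 stands at the weak end of the two values shown. The step of an at least 4.2-fold higher number from compound 1 to compound 2 (0.62 log units; beyond the scatter) is therefore known only as a lower bound; this rests on (the limit of > 100000 nM in this assay, at which 1 of the 2 values shown sits).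

Compound 3, `CC1=CC[C@@H]([C@@](C)(O)CCCC(C)(C)NC(=S)N/N=C\c2ccccc2[N+](=O)[O-])CC1`, has not yet been measured. It differs from compound 2 by 2-nitrophenyl in place of 4-(dimethylamino)phenyl on a carbon with a double bond to nitrogen. Going by the values given here, the one measured step, an at least 4.2-fold higher number from compound 1 to compound 2 (0.62 log units; beyond the scatter), concerns the same ring but a different substituent in a different place, so it speaks to the new change only loosely: it shows that a substituent on this ring can weaken growth inhibition considerably. Compound 3 is expected to land near compound 1 or somewhat weaker, with a step of an at least 2.8-fold lower number from compound 2 to compound 3 (0.45 log units; beyond the scatter) that is uncertain in size. The estimated value for compound 3 is 35000 nM, within a range from 10000 nM to 120000 nM.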

Compound 3, concentration for total growth inhibition: > 100000 nM
Compound 3 ended at the assay's limit; the forecaster's own chance of this, stated with the estimate: 35%; at least 2.8-fold (0.45 log units) between middle value and limit.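

In this assay, compound 3 gives > 100000 nM, which is a limit of the assay and not a number. Putting nitro on the ring of compound 1 gives an at least 4.2-fold higher number from compound 1 to compound 3 (0.62 log units; beyond the scatter), so a second substituent, the 2-nitrophenyl group rather than the 4-(dimethylamino)phenyl group, also leaves growth inhibition clearly weaker than with the unsubstituted ring; among these three compounds, both substituted rings fall on the weak side of compound 1, and none goes against this. The step between the two substituted compounds cannot be read, and the two groups cannot be ranked against each other, because both values sit at the same limit: the limit of > 100000 nM in this assay, at which 2 of the 3 values shown sit.

On these data alone, whether the loss depends on the kind of group or on where it sits on the ring stays open, as the two substituted rings differ in both. It is also unknown whether a smaller group on this ring, such as a fluorine atom, a methyl or a hydroxyl, would keep the growth inhibition of compound 1 or improve on it.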